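Fluorine on the Benzoyl Ring: Expected Cytotoxicity of Compound 4

The source may report more compounds than this note shows. Statements on the series, on what has been measured and on what is new or still open speak of the compounds shown alone.

Compound 1, `Cc1c(Cc2c(F)cccc2Cl)nc(SCC(=O)c2ccccc2)[nH]c1=O`, gives > 12000 nM in an ADME assay on MT4 cells (Homo sapiens) for cytotoxicity, read by MTT assay; a higher number here means that more compound is tolerated, a lower number that less compound is tolerated. Compound 2, `Cc1c(Cc2c(F)cccc2Cl)nc(SCC(=O)c2ccc(F)cc2)[nH]c1=O`, gives > 59000 nM. Compound 3, `CC(C)c1c(Cc2c(F)cccc2F)nc(SCC(=O)c2ccccc2)[nH]c1=O`, gives > 60000 nM.

Each of these values is a limit of this assay rather than a measured number. For compound 1 it is the limit of > 12000 nM in this assay, at which 1 of the 3 values shown sits. For compound 2 it is the limit of > 59000 nM in this assay, at which 1 of the 3 values shown sits. For compound 3 it is the limit of > 60000 nM in this assay, at which 1 of the 3 values shown sits.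

Compound 1 and compound 2 differ by fluoro in place of hydrogen on an aromatic carbon, and that step reads a step that the two limits leave unreadable from compound 1 to compound 2. How the core of compound 1 differs from the core of compound 3 is not broken down here.

Compound 4, `CC(C)c1c(Cc2c(F)cccc2F)nc(SCC(=O)c2ccc(F)cc2)[nH]c1=O`, is not yet measured. It differs from compound 3 by fluoro in place of hydrogen on an aromatic carbon, the same change at the same kind of place as between compound 1 and compound 2. For compound 4 a step that the limit leaves unreadable from compound 3 to compound 4 is expected, resting on compound 3 showing only a limit at > 60000 nM and on the earlier step being unreadable at a step that the two limits leave unreadable from compound 1 to compound 2. Compound 4 is estimated at 80000 nM, most likely again reported as a limit, within 30000 nM to 200000 nM.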

Compound 4, half-maximal cytotoxic concentration: > 58000 nM
Compound 4 gave a limit, no number (the forecaster's own chance of this, stated with the estimate: 85%); the middle value lies beyond the limit too.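

In this assay compound 4 gives only a limit of the assay, not a number: the limit of > 58000 nM in this assay, at which 1 of the 4 values shown sits.

Compound 3 also gives only a limit, so the size of the step between compound 3 and compound 4 cannot be read. The compounds shown leave open what concentration of any of them is actually tolerated, and whether fluoro in place of hydrogen changes it at all.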